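Ethyl on the Amide Nitrogen in Two Related Cores

The compounds below may be only part of what the source reports. "The series", "measured", "known", "first", "only" and "open" are said of these compounds alone.

Of the compounds shown here, three from this series have been measured in an assay on membranes from CHO cells for displacement of a labelled ligand from adenosine receptor A1 (Homo sapiens), read by scintillation counting, with a stated time of 60 min, tested at 1 uM; a higher number here means more inhibition at the concentration tested (going by the name of the read-out), a lower number less inhibition. Compound 1 `CCNC(=O)C1=C(C)NC(=O)NC1c1ccoc1` gives 1%. Compound 2 `CCN(CC)C(=O)C1=C(C)NC(=O)NC1c1ccoc1`, which carries one more ethyl group, gives 15% in this assay. The change between them is ethyl in place of hydrogen on an amide-type nitrogen, and it produced a number 14 percentage points higher from compound 1 to compound 2 (beyond the scatter). Compound 3 `CC1=C(C(N)=O)C(c2ccsc2)NC(=O)N1` gives 2% in this assay; its number stands close to that of compound 1, and the gap to compound 2 is larger, as the values themselves show. The difference between the core of compound 3 and the core of compound 1 is not broken down here.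

Compound 4 `CCNC(=O)C1=C(C)NC(=O)NC1c1ccsc1` has not yet been measured in this assay. It differs from compound 3 by ethyl in place of hydrogen on an amide-type nitrogen. Going by the values given here, this is the same kind of change as the one from compound 1 to compound 2, but not the same: there the amide-type nitrogen had a carbonyl carbon and a saturated chain carbon as its other neighbours, whereas in compound 3 its only other neighbour is the carbonyl carbon. Compound 4 is expected to sit low, because compound 1, which carries the same ethylcarbamoyl group on a related core, gives 1%. A step of a number 2 percentage points higher from compound 3 to compound 4 (within the scatter) is therefore estimated from compound 3 to compound 4, well short of the earlier one. Compound 4 is expected to give about 4% in this assay, with a range from 0% to 15%.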

Compound 4, a percentage reported as inhibition, at one concentration (the size of the read-out at that concentration, not a potency): 3%
For compound 4 the middle estimate is 1 percentage points above the measured one; measured number inside the range.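

In this assay, ethyl in place of hydrogen on the amide-type nitrogen gave a number 1 percentage points higher from compound 3 to compound 4 (within the scatter), and set beside the earlier step the two do not separate: the same change on two cores in this assay, a number 14 percentage points higher (beyond the scatter) from compound 1 to compound 2 and a number 1 percentage points higher (within the scatter) from compound 3 to compound 4, 13 percentage points apart, within the scatter of two such steps. Going by these compounds alone, this does not show that the change behaves differently on the two cores, nor does it show that the change carries over unchanged, since there are only two pairs, the amide-type nitrogen has different neighbours in each, and the larger step rests on a single pair. Thiophen-3-yl in place of furan-3-yl, with the ethylcarbamoyl group kept, gave a number 2 percentage points higher from compound 1 to compound 4 (within the scatter), so this pair offers no sign that the ring group alone alters the read-out at the concentration tested, though it cannot say how the ring group would act with any other amide.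

Still open, as far as these compounds go, is whether a second ethyl on the amide nitrogen of compound 4, matching the diethylamide of compound 2, would bring the same rise with thiophen-3-yl in place of furan-3-yl. Also open, from the compounds shown here alone, is how a longer chain such as butyl on that nitrogen, or a carboxylic acid in place of the amide, would read in this assay.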